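The source may report more compounds than this note shows. Statements on the series, on what has been measured and on what is new or still open speak of the compounds shown alone.

Compound 1 `CCSc1ccc(-c2cncnc2-c2cc(OC)c(OC)c(OC)c2)cc1`: 370 nM
Compound 2 `COc1cc(-c2ncncc2-c2ccc(OCC(F)(F)F)cc2)cc(OC)c1OC`: 10200 nM
Compound 3 `COc1ccc(-c2cncnc2-c2cc(OC)c(OC)c(OC)c2)nc1`: 470 nM

These values come from a functional assay on HeLa cells (Homo sapiens) for antiproliferative activity, read by CCK-8 assay, with a stated time of 72 h; on this read-out lower numbers stand for stronger inhibition and higher numbers for weaker inhibition. Compound 3, at 470 nM, sits with compound 1 at the low end of the three numbers, and compound 2, at 10200 nM, has a much higher number than both.

Compound 4 `COc1cc(-c2ncncc2-c2ccc(C(N)=O)cc2)cc(OC)c1OC` keeps the shared core but carries 4-carbamoylphenyl in place of 5-methoxypyridin-2-yl on an aromatic carbon. Among the compounds with values here, two measured steps bear on this change, since both alter the group that changes here. One of them, a 1.3-fold higher number from compound 1 to compound 3 (0.10 log units; within the scatter), shows that a quite different group can leave the number where it was. The other, a 28-fold higher number from compound 1 to compound 2 (1.44 log units; beyond the scatter), shows that a single change in this group can cost a great deal. Within the data shown here, no compound with a carbamoyl group has been measured yet, so neither step settles the outcome. The large rise seen with compound 2 a 28-fold higher number from compound 1 to compound 2 (1.44 log units; beyond the scatter) tilts the expectation upward, though a step of that full size is not assumed, and the range must stay wide.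

In this assay, an estimated 5.3-fold higher number from compound 3 to compound 4 (0.73 log units; beyond the scatter) is therefore expected. The expected value for compound 4 is 2500 nM, with an estimated range from 450 nM to 14000 nM.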

Compound 4, half-maximal inhibitory concentration: > 100000 nM
Compound 4 gave a limit, no number; the forecaster's own chance of this, stated with the estimate: 12%; middle value at least 40-fold (1.60 log units) away from the limit.
By their numbers in this assay, from the lowest: compounds 1 and 3 (each within the scatter of the next); then compound 2. At a limit, above all of these: compound 4.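

In this assay compound 4 gave only a limit of the assay and no number: the limit of > 100000 nM in this assay, at which 1 of the 4 values shown sits. Exchanging 5-methoxypyridin-2-yl for 4-carbamoylphenyl gives an at least 210-fold higher number from compound 3 to compound 4 (2.32 log units; beyond the scatter), and placing carbamoyl where compound 1 has ethylsulfanyl gives an at least 270-fold higher number from compound 1 to compound 4 (2.43 log units; beyond the scatter), so this position can be far less forgiving than the near match of compound 1 and compound 3 suggested. Even the costly 2,2,2-trifluoroethoxy group of compound 2 is surpassed, with an at least 9.8-fold higher number from compound 2 to compound 4 (0.99 log units; beyond the scatter), which shows that the drop seen with compound 2 was not the largest this position allows.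

The entering 4-carbamoylphenyl group has a hydrogen-bond donor and 5-methoxypyridin-2-yl has none, but these four compounds cannot tell whether that difference, or some other feature of the carbamoyl group, lies behind the step, and the limit hides its full size. A carboxylic acid, a methyl ester or an aminomethyl group in place of carbamoyl would help to separate these possibilities, and so would an N-methyl amide, which keeps the amide but changes its nitrogen.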